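A few compounds are considered here, and "the series" means these few. Any claim that something is new, unique, unknown or untested is made for them only; others in the source may bear on it.

Series notes. Compound 1 `CN(C)C(=O)c1cc2cnc(Nc3ccc(S(=O)(=O)NCCCCCCN=C=S)cc3)nc2n1C1CCCC1` and compound 2 `CN(C)C(=O)c1cc2cnc(Nc3ccc(S(=O)(=O)NCCCCCCCN=C=S)cc3)nc2n1C1CCCC1` share a core and differ by a group of 4 heavy atoms (2 carbon, 1 nitrogen, 1 sulfur; no ring) in place of a group of 3 heavy atoms (1 carbon, 1 nitrogen, 1 sulfur; no ring), on a saturated chain carbon, six bonds along the chain from a sulfonamide nitrogen; in a functional assay on A549 cells (Homo sapiens) for inhibition, read by CCK-8 assay, with a stated time of 72 h, tested at 1 uM (a higher number here means a stronger effect of the compound at the concentration tested, a lower number a weaker effect), compound 1 gives 49.5%, compound 2 gives 32.6%, and the step is a number 16.9 percentage points lower from compound 1 to compound 2 (beyond the scatter). Compound 3 `CN(C)C(=O)c1cc2cnc(Nc3ccc(NC(=O)CCCCN=C=S)cc3)nc2n1C1CCCC1` gives 38.2% in this assay; the difference between the core of compound 3 and that of compound 1 is not broken down here. Compound 4 `CN(C)C(=O)c1cc2cnc(Nc3ccc(NC(=O)CCCCCN=C=S)cc3)nc2n1C1CCCC1` is not yet measured. It differs from compound 3 by a group of 4 heavy atoms (2 carbon, 1 nitrogen, 1 sulfur; no ring) in place of a group of 3 heavy atoms (1 carbon, 1 nitrogen, 1 sulfur; no ring), on a saturated chain carbon, four bonds along the chain from a carbonyl carbon, the same kind of change as from compound 1 to compound 2, though the place differs: here four bonds along the chain from a carbonyl carbon, there six bonds along the chain from a sulfonamide nitrogen. Because compound 2 shows a number 16.9 percentage points lower from compound 1 to compound 2 (beyond the scatter), compound 4 is expected to give a step of a number 11.2 percentage points lower from compound 3 to compound 4 (beyond the scatter), with an estimate of 27%, between 13% and 41%.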

Compound 4, a percentage reported as inhibition, at one concentration (the size of the read-out at that concentration, not a potency): 56.1%
Compound 4: middle estimate off by 29.1 percentage points, on the low side, outside the stated range (above it).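

In this assay the change on the core of compound 3 gives a number 17.9 percentage points higher from compound 3 to compound 4 (beyond the scatter). Set beside the earlier step, the same change does not keep its direction from one core to the other: the same change on two cores in this assay, a number 16.9 percentage points lower (beyond the scatter) from compound 1 to compound 2 and a number 17.9 percentage points higher (beyond the scatter) from compound 3 to compound 4, 34.8 percentage points apart, beyond the scatter of two such steps This shows that, within these two pairs, the outcome of the change on one core cannot be carried over to the other; it does not show which difference between the cores matters, nor does it give a rule for the wider series.

As far as these compounds go, whether a longer chain on the core of compound 3 would extend the rise or reverse it remains open. Also open, from the compounds shown here alone, is whether a shorter chain on the core of compound 1 would change the read-out, and how an amine at the chain end would compare.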